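The source may hold more compounds than are shown below. What is called first, only, known or untested is meant among the compounds shown, and "the series" means these compounds.

Values in a functional assay on HepG2 cells (Homo sapiens) for inhibition, read by MTT assay, with a stated time of 24 h (on this read-out higher numbers stand for weaker inhibition and lower numbers for stronger inhibition), for the measured members of the series:

compound 1 `CC1(C)[C@H]2CC[C@]1(C)N(Cc1cn(-c3ccccc3F)nn1)C(=O)C2`: 60 nM
compound 2 `CC1(C)[C@H]2CC[C@]1(C)N(Cc1cn(-c3ccc(F)cc3)nn1)C(=O)C2`: 90 nM
compound 3 `CC1(C)[C@H]2CC[C@]1(C)N(Cc1cn(-c3ccccc3O)nn1)C(=O)C2`: 120 nM

Compound 2 holds the second highest of the three numbers in this assay. Its nearest neighbour is given by a 1.3-fold higher number from compound 2 to compound 3 (0.12 log units; within the scatter) and its furthest by a 1.5-fold higher number from compound 1 to compound 2 (0.18 log units; within the scatter); all three measured compounds therefore sit inside one band of scatter, and no order among them can be read from these figures.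

The next compound, compound 4 `CC1(C)[C@H]2CC[C@]1(C)N(Cc1cn(-c3ccc(Cl)cc3)nn1)C(=O)C2`, differs from compound 2 in one place: chloro in place of fluoro on an aromatic carbon. For the measured compounds named here, no measured step exchanges fluoro for chloro anywhere in this set, so the bearing of the earlier steps is indirect. The three changes on the aryl ring that have been measured — a 1.5-fold higher number from compound 1 to compound 2 (0.18 log units; within the scatter), a 2.0-fold higher number from compound 1 to compound 3 (0.30 log units; within the scatter) and a 1.3-fold higher number from compound 2 to compound 3 (0.12 log units; within the scatter) — all stayed within the scatter, whether the substituent moved or changed identity. On that basis the expectation for compound 4 is a step of no more than the scatter, with no preferred direction: no change at the digits printed from compound 2 to compound 4 (within the scatter). Compound 4 is thus estimated at 90 nM in this assay, with a range from 45 nM to 180 nM.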

Compound 4, half-maximal inhibitory concentration: 90 nM
The estimate for compound 4 equals the measured number at the digits printed; low and high end bracket the measured number.
By their numbers in this assay, from the lowest: compounds 1, 2, 4 and 3 (each within the scatter of the next).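

In this assay, for the compounds shown here, the first direct exchange of fluoro for chloro, on an aromatic carbon para to a large group, gives no change at the digits printed from compound 2 to compound 4 (within the scatter) and so does not separate 4-fluorophenyl from 4-chlorophenyl. Placing 4-chlorophenyl where 2-hydroxyphenyl stood gives a 1.3-fold lower number from compound 3 to compound 4 (0.12 log units; within the scatter) and placing it where 2-fluorophenyl stood gives a 1.5-fold higher number from compound 1 to compound 4 (0.18 log units; within the scatter) and neither step sets compound 4 apart from the others. The chloro group therefore joins fluoro and hydroxy in a single band of scatter, and the aryl changes seen so far give no order among the four compounds.

From the compounds shown here alone, whether an amine, a carboxylic acid or a longer chain at this same carbon would move the number beyond the scatter remains open. No measurement beyond these values is available to account for how narrow the spread is.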